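A few compounds are considered here, and "the series" means these few. Any claim that something is new, unique, unknown or untested is made for them only; others in the source may bear on it.

Measured in an ADME assay on MT4 cells (Homo sapiens) for cytotoxicity, read by MTT assay, with a stated time of 4 days; a higher number here means that more compound is tolerated, a lower number that less compound is tolerated:
- compound 1 (`COc1cccc(-c2oc3ccc(NC(C)=O)cc3c(=O)c2OC)c1`): 369000 nM
- compound 2 (`COc1c(-c2ccccc2)oc2ccc(N)cc2c1=O`): 126000 nM

Compound 2 holds the lower of the two numbers (126000 nM), and the gap to compound 1 (369000 nM) lies beyond the scatter. Compound 3 (`COc1cccc(-c2oc3ccc(N)cc3c(=O)c2OC)c1`) is compound 2 with methoxy in place of hydrogen on an aromatic carbon. Going by the values given here, no measured pair shows this change, so in this assay a step within the scatter is expected, if anything slightly upward. The estimated step is small (a 1.3-fold higher number from compound 2 to compound 3 (0.10 log units; within the scatter)). Compound 3 is expected near 160000 nM, within an estimated range of 70000 nM to 370000 nM.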

Compound 3, half-maximal cytotoxic concentration: 251000 nM
For compound 3 the middle estimate is 1.6-fold (0.20 log units) below the measured one, within the range that was stated.
By their numbers in this assay, from the lowest: compounds 2, 3 and 1 (each within the scatter of the next, the first and the last beyond it).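

In this assay, going by these compounds alone, methoxy in place of hydrogen on an aromatic carbon, meta to a large group, gives a 2.0-fold higher number from compound 2 to compound 3 (0.30 log units; within the scatter), the first reading of this change at this position. Hydrogen in place of acetyl on a nitrogen on an aromatic ring can now be read alone and gives a 1.5-fold lower number from compound 1 to compound 3 (0.17 log units; within the scatter). No measured evidence bears on either step. As far as these compounds go, how a carboxylic acid or a longer chain would read on this aromatic carbon stays open. So does the outcome of methoxy in place of hydrogen with acetyl on the nitrogen.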